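The source may report more compounds than this note shows. Statements on the series, on what has been measured and on what is new or still open speak of the compounds shown alone.

The measured compounds:
compound 1, `COc1cc(C(=O)c2sc(-c3ccc(Br)cc3)cc2N)cc(OC)c1OC`: in a functional assay on CCRF-CEM cells (Homo sapiens) for antiproliferative activity (on this read-out lower numbers stand for stronger inhibition and higher numbers for weaker inhibition), compound 1 gives 86 nM
compound 2, `COc1cc(C(=O)c2sc(-c3ccc([N+](=O)[O-])cc3)cc2N)cc(OC)c1OC`: in this assay compound 2 gives 99 nM
compound 3, `COc1cc(C(=O)c2sc(-c3cccc([N+](=O)[O-])c3)cc2N)cc(OC)c1OC`: in this assay compound 3 gives 5.9 nM

Compound 1 stands second highest of the three numbers; its nearest neighbour is compound 2, reached by a 1.2-fold higher number from compound 1 to compound 2 (0.06 log units; within the scatter), while the step to compound 3 is a 15-fold lower number from compound 1 to compound 3 (1.16 log units; beyond the scatter). Compound 4, `COc1cc(C(=O)c2sc(-c3ccccc3)cc2N)cc(OC)c1OC`, differs from compound 1 by hydrogen in place of bromo on an aromatic carbon. Among the measured compounds shown here, only the step from compound 1 to compound 2 bears on this, since it too exchanges the bromo group in the same place, and it was a 1.2-fold higher number from compound 1 to compound 2 (0.06 log units; within the scatter). The large steps of a 15-fold lower number from compound 1 to compound 3 (1.16 log units; beyond the scatter) and a 17-fold lower number from compound 2 to compound 3 (1.22 log units; beyond the scatter) concern a shift of the nitro group and say nothing about a plain removal. Compound 4 is therefore expected to show a 1.4-fold higher number from compound 1 to compound 4 (0.14 log units; within the scatter), not beyond the scatter. The estimate for compound 4 is 120 nM, with a range of 50 nM to 300 nM.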

Compound 4, half-maximal inhibitory concentration: 4.5 nM
Beside the measured number, compound 4's estimate is 27-fold (1.43 log units) above it; the measured number lies below the stated range.
By their numbers in this assay, from the lowest: compounds 4 and 3 (each within the scatter of the next); then compounds 1 and 2 (each within the scatter of the next).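

Taking the bromo group off altogether (a 19-fold lower number from compound 1 to compound 4 (1.28 log units; beyond the scatter)) shows that in this assay the para position of the 4-bromophenyl group does better with plain hydrogen, and the nitro group in that place falls short in the same way (a 22-fold lower number from compound 2 to compound 4 (1.34 log units; beyond the scatter)). The 3-nitrophenyl compound, by contrast, stays within the scatter of the unsubstituted phenyl (a 1.3-fold lower number from compound 3 to compound 4 (0.12 log units; within the scatter)), so only the two 4-substituted compounds carry the weaker numbers. Nothing available gives a reason for this. From the compounds shown here alone, whether a fluoro group or a carboxylic acid in the place of the bromo would behave like hydrogen or like bromo remains open.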